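The source may report more compounds than this note shows. Statements on the series, on what has been measured and on what is new or still open speak of the compounds shown alone.

Four closely related compounds were examined for their effect on human cells in a functional assay on HeLa cells (Homo sapiens) for cytotoxicity, read by CCK-8 assay, with a stated time of 24 h; a lower number here means a stronger inhibitor, a higher number a weaker inhibitor. Compound 1 `C/C(=C\c1cc(-c2ccc(C)cc2)co1)C(N)=O` carries a methyl group on its outer aromatic ring, and in this assay compound 1 gives 12000 nM. Compound 2 `C/C(=C\c1cc(-c2ccc(F)cc2)co1)C(N)=O` differs from compound 1 in one place only, (fluoro in place of methyl on an aromatic carbon), and in this assay compound 2 gives 11800 nM. That change produced a 1.0-fold lower number from compound 1 to compound 2 (0.01 log units; within the scatter), so these two compounds cannot be told apart on this measurement.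

Compound 3 `C/C(=C\c1nc(-c2ccc(C)cc2)cs1)C(N)=O` keeps the methyl-bearing aromatic ring but is built on a different core; the difference between the two cores is not broken down here. In this assay compound 3 gives 25000 nM, the highest of the three numbers, and its gap to compound 1 and to compound 2 lies beyond the scatter.

Compound 4 `C/C(=C\c1nc(-c2ccc(F)cc2)cs1)C(N)=O` has not yet been measured. It differs from compound 3 by fluoro in place of methyl on an aromatic carbon, the same change, made at the same place on the ring, that turned compound 1 into compound 2. Because the earlier step of a 1.0-fold lower number from compound 1 to compound 2 (0.01 log units; within the scatter) lay within the scatter, the expected step is no change at the digits printed from compound 3 to compound 4 (within the scatter), again small. Compound 4 is estimated at 25000 nM in this assay, with the value expected to fall between 12000 nM and 50000 nM.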

Compound 4, half-maximal inhibitory concentration: 5400 nM
Beside the measured number, compound 4's estimate is 4.6-fold (0.67 log units) above it; the whole stated range lies above it.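

The swap of methyl for fluoro on the outer aromatic ring did not carry over unchanged from one core to the other in this assay: on the core of compound 3 it gave a 4.6-fold lower number from compound 3 to compound 4 (0.67 log units; beyond the scatter), whereas on the core of compound 1 it gave a 1.0-fold lower number from compound 1 to compound 2 (0.01 log units; within the scatter). The gap between these two results is larger than chance variation between repeated measurements would readily explain, so the effect of this swap depends on the core that carries it: the same change on two cores in this assay, a 1.0-fold lower number (0.01 log units; within the scatter) from compound 1 to compound 2 and a 4.6-fold lower number (0.67 log units; beyond the scatter) from compound 3 to compound 4, 4.6-fold (0.66 log units) apart, beyond the scatter of two such steps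

Among the compounds shown here, this rests on only two matched pairs, however, and it does not show why the cores respond differently, nor does it predict what the same swap would do on any further core.

The compounds shown leave open whether a chloro or methoxy group, or simply a hydrogen, at the same place on the outer ring would also separate the two cores in this way. They also leave open how a carboxylic acid or a nitrile in place of the amide would behave on either core, and whether the lower number of compound 4, at 5400 nM, would hold up in other cell types.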